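The source may report more compounds than this note shows. Statements on the series, on what has been measured and on what is new or still open speak of the compounds shown alone.

Working notes on the series. Three compounds have been run in a functional assay on the whole organism (strain Wister albino) for inhibition, with Rattus norvegicus as the target, read by paw edema, with stated times of 1 h and 2 h, at a dose of 50 mg/kg by the intraperitoneal route; on this read-out lower numbers stand for less inhibition and higher numbers for more inhibition at the one dose given (going by the name of the read-out). Compound 1 `Cc1ccc([C@@H]2CN(C)[C@]3(C(=O)Nc4ccccc43)[C@]23Cc2ccccc2C3=O)cc1` gives 23.8%. Compound 2 `CN1C[C@@H](c2ccc(F)cc2)[C@@]2(Cc3ccccc3C2=O)[C@@]12C(=O)Nc1ccccc12` gives 21.2%. Compound 3 `CN1C(=O)[C@@]2(c3ccccc31)N(C)C[C@@H](c1ccc(F)cc1)[C@@]21Cc2ccccc2C1=O` gives 24.6%. Compound 2 holds the lowest of the three numbers, but both neighbours lie within the scatter: a number 2.6 percentage points lower from compound 1 to compound 2 (within the scatter) and a number 3.4 percentage points higher from compound 2 to compound 3 (within the scatter). Compound 4 `CN1C[C@@H](c2ccc(Cl)cc2)[C@@]2(Cc3ccccc3C2=O)[C@@]12C(=O)Nc1ccccc12` is not yet measured; it differs from compound 2 by chloro in place of fluoro on an aromatic carbon. Among the compounds with values here, only one measured step bears on this, the change of the group on the same aromatic carbon from compound 1 to compound 2, and it stayed within the scatter. The step from compound 3 concerns a different position and gives no further guidance. The expected step in this assay is therefore a number 1.8 percentage points higher from compound 2 to compound 4 (within the scatter), nothing beyond the scatter. Compound 4 is expected to give 23%, in the range 13% to 33%.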

Compound 4, a percentage reported as inhibition, in the whole organism at one dose (the size of the read-out at that dose, not a potency): 28.4%
Compound 4: middle estimate off by 5.4 percentage points, on the low side; measured number inside the range.
By their numbers in this assay, from the lowest: compounds 2, 1, 3 and 4 (each within the scatter of the next).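

In this assay, chloro is a third group on this aromatic carbon, para to a large group, and it stays within the scatter of both earlier groups, fluoro (a number 7.2 percentage points higher from compound 2 to compound 4 (within the scatter)) and methyl (a number 4.6 percentage points higher from compound 1 to compound 4 (within the scatter)). Across methyl, fluoro and chloro, this position therefore shows no separation beyond the scatter. Nothing available gives a reason for this result. Still open, going by these compounds, is whether a group of another kind here, such as an amine, a carboxylic acid or a longer chain, would give a step beyond the scatter.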